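The source may hold more compounds than are shown below. What is called first, only, known or untested is meant among the compounds shown, and "the series" means these compounds.

Of the compounds shown here, two carrying the same core have already been tested in an ADME assay on HepG2 2.2.15 cells (Homo sapiens) for cytotoxicity; on this read-out lower numbers stand for higher toxicity in this test and higher numbers for lower toxicity in this test. Compound 1 `Cc1ccc(C(=O)Nc2ncc(C(Oc3ccc4cc(Br)ccc4c3)c3ccc(Cl)cc3)s2)cc1` bears an amide on the core, and in this assay compound 1 is reported as "not toxic" (no number reported), with no number attached. Compound 2 `O=S(=O)(Nc1ncc(C(Oc2ccc3cc(Br)ccc3c2)c2ccc(Cl)cc2)s1)c1ccccc1` carries a phenylsulfonyl group on the same nitrogen instead, and in this assay compound 2 reaches only a limit of the test, > 50000 nM, which is an edge of the measurable range rather than a number. This is the limit (the limit of > 50000 nM in this assay, at which 1 of the 2 values shown sits), so the place of compound 2 on the scale can only be given as lying at that edge.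

Compound 3 `Cc1ccc(C)c(S(=O)(=O)Nc2ncc(C(Oc3ccc4cc(Br)ccc4c3)c3ccc(Cl)cc3)s2)c1` differs from compound 2 in one place: 2,5-dimethylphenyl in place of phenyl on a sulfonyl sulfur. For the measured compounds named here, no measured pair shows what such a change does here, so the expectation rests on compound 2 alone. The step from compound 2 to compound 3 is expected to be a number no higher from compound 2 to compound 3 (the limit leaves the size open), that is, nothing beyond the usual scatter. Compound 3 is therefore estimated at 50000 nM, within a range from 25000 nM to 100000 nM, most likely again as a limit.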

Compound 3, half-maximal cytotoxic concentration: > 50000 nM
Compound 3: no number, only a limit; the forecaster's own chance of this, stated with the estimate: 80%; the middle value lies on the limit itself.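

For the compounds shown here, compound 3, like compound 2, gives only a limit and not a number, so no step between these two compounds can be read in this assay: the limit of > 50000 nM in this assay, at which 2 of the 3 values shown sit.

The compounds shown leave open at what concentration, if any, this core becomes toxic to these cells, and whether phenyl and 2,5-dimethylphenyl differ in that respect.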